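The compounds below may be only part of what the source reports. "The series", "measured", "known", "first", "only" and "open" are said of these compounds alone.

Measured so far:
- compound 1 `Cc1ccc(C)c(NC(=O)[C@@H]2CCCN2S(=O)(=O)c2cccc3cccnc23)c1`: 30900 nM
- compound 2 `COc1ccc(C)c(NC(=O)[C@@H]2CCCN2S(=O)(=O)c2cccc3cccnc23)c1`: 44200 nM

Among the measured compounds shown here, in an ADME assay on HEp-2 cells (Homo sapiens) for cytotoxicity (a lower number here means that less compound is tolerated, a higher number that more compound is tolerated), compound 2 gives 44200 nM, which lies within the scatter of compound 1, the only other compound measured. The next compound is compound 3 `Cc1ccc(Cl)c(NC(=O)[C@@H]2CCCN2S(=O)(=O)c2cccc3cccnc23)c1`, which keeps the shared core and changes one group: 2-chloro-5-methylphenyl in place of 5-methoxy-2-methylphenyl on an amide-type nitrogen. In short, 2-chloro-5-methylphenyl replaces 5-methoxy-2-methylphenyl on an amide-type nitrogen.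

For the measured compounds named here, only one measured step bears on this group: a 1.4-fold higher number from compound 1 to compound 2 (0.16 log units; within the scatter). That step, methoxy in place of methyl on an aromatic carbon, stays within the scatter. Going by the values given here, no compound with a chloro group has been measured, so the size of this exchange has no direct precedent, and two compounds are a thin basis. Among the compounds with values here, with only that small step to go on, no change beyond the scatter is expected in this assay, and no direction is firmly indicated.

The expected step is a 1.3-fold lower number from compound 2 to compound 3 (0.13 log units; within the scatter), which is a small one. For compound 3 the estimated value is 33000 nM, with an expected range of 13000 nM to 80000 nM.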

Compound 3, half-maximal cytotoxic concentration: > 50000 nM
Compound 3: only a limit was reported; the forecaster's own chance of this, stated with the estimate: 15%; at least 1.5-fold (0.18 log units) between middle value and limit.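

In this assay, among the compounds shown here, compound 3 gives > 50000 nM, which is a limit of the assay and not a number, and the only reading of that kind: the limit of > 50000 nM in this assay, at which 1 of the 3 values shown sits. Read as floors only, the exchange of 5-methoxy-2-methylphenyl for 2-chloro-5-methylphenyl on the amide-type nitrogen gives an at least 1.1-fold higher number from compound 2 to compound 3 (0.05 log units; that floor lies within the scatter), and chloro in place of methyl on an aromatic carbon gives an at least 1.6-fold higher number from compound 1 to compound 3 (0.20 log units; that floor lies within the scatter). For the compounds shown here, this is the first chloro group measured on this aromatic ring, and it shows that the exchange does not bring the number down, while neither floor establishes a step beyond the scatter and the true size of both steps stays unknown.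

The compounds shown leave open how far the number of compound 3 lies from its limit, and so whether the chloro exchange has any real effect in this assay at all. They also leave open whether the number holds up with an amine or a carboxylic acid on this aromatic ring, or with a longer chain in place of the methyl group.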